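The compounds below may be only part of what the source reports. "The series", "measured", "known", "first", "only" and "open" are said of these compounds alone.

Within the data shown here, compound 3 `NS(=O)(=O)NCCC1CCN(c2cc(-c3cccc(Cl)c3)ncn2)CC1` gives 50700 nM in a functional assay on M21 cells (Homo sapiens) for antiproliferative activity, read by sulforhodamine B assay, with a stated time of 48 h (a lower number here means a stronger inhibitor of growth, a higher number a weaker inhibitor of growth), the lower of the two numbers known here. Compound 2 `COc1ccc(-c2cc(N3CCC(CCNS(N)(=O)=O)CC3)ncn2)cc1` gives 69800 nM in this assay, and the move a 1.4-fold lower number from compound 2 to compound 3 (0.14 log units; within the scatter) shows that swapping the aryl group on the shared core barely shifted the number. Compound 1 `NS(=O)(=O)NCC1CCN(c2cc(-c3ccccc3Cl)ncn2)CC1` gives > 100000 nM in this assay, a limit of the measurement rather than a number (the limit of > 100000 nM in this assay, at which 1 of the 3 values shown sits).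

Compound 4 `NS(=O)(=O)NCCC1CCN(c2cc(-c3ccccc3Cl)ncn2)CC1` arises from compound 3 by 2-chlorophenyl in place of 3-chlorophenyl on an aromatic carbon, so the chlorine moves within the same aryl ring while the rest is unchanged. Among the measured compounds shown here, only one measured step, the one from compound 2 to compound 3, involves the aryl group, and it was within the scatter. The reading for compound 1, which carries the 2-chlorophenyl group on a shorter chain, is a limit and so points toward the weak end. For compound 4 the expected step is a 1.8-fold higher number from compound 3 to compound 4 (0.25 log units; within the scatter), toward a weaker number. Compound 4 is therefore estimated at 90000 nM, between 35000 nM and 250000 nM, with a fair chance that only a limit is reported.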

Compound 4, concentration for 50% growth inhibition: 93900 nM
Compound 4: middle estimate off by 1.0-fold (0.02 log units), on the low side, and the stated range covers the measured number.
By their numbers in this assay, from the lowest: compounds 3, 2 and 4 (each within the scatter of the next). At a limit, above all of these: compound 1.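

In this assay, 2-chlorophenyl in place of 3-chlorophenyl gives a 1.9-fold higher number from compound 3 to compound 4 (0.27 log units; within the scatter), and 2-chlorophenyl in place of 4-methoxyphenyl gives a 1.3-fold higher number from compound 2 to compound 4 (0.13 log units; within the scatter), so these three aryl groups on the shared core cannot be told apart at this position. The chain change, with (sulfamoylamino)methyl in place of sulfamoylamino, gives an at least 1.0-fold lower number from compound 1 to compound 4 (0.02 log units; that floor lies within the scatter), and that floor does not show a real difference between the two chains. Compound 1 stands as a limit rather than a number: the limit of > 100000 nM in this assay, at which 1 of the 4 values shown sits.

On these data alone, how far compound 1 actually lies from compound 4 stays open, so the true effect of the chain is unknown. Also open, as far as these compounds go, is whether an aryl ring carrying an amine or a carboxylic acid, or a longer chain, would move the number beyond the scatter.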